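This account rests on a few compounds, and the source may have more. Where it says the series, first, only, none or still open, it means among the compounds named here.

Of the compounds shown here, three sharing one core have been measured in an ADME assay on Vero cells (Chlorocebus sabaeus) for cytotoxicity, read by neutral red uptake, tested at 3150 ug/mL; on this read-out higher numbers stand for a weaker effect at the one concentration tested and lower numbers for a stronger effect. Compound 1 `O=C1CSC(c2c(Cl)cccc2Cl)N1CCN1CCCCC1` gives 7%, compound 2 `O=C1CSC(c2cccc(Cl)c2)N1CCN1CCCCC1` gives 15%, and compound 3 `O=C1CSC(c2ccccc2[N+](=O)[O-])N1CCN1CCCCC1` gives 30%. Among these three numbers compound 2 stands second highest; its nearest neighbour is compound 1, whose number lies within the usual scatter of it, and the furthest is compound 3, whose number lies beyond the scatter. Among the compounds with values here, no two of the measured compounds differ in a single place, so no step can be read off directly.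

Compound 4 `Cc1ccc(C2SCC(=O)N2CCN2CCCCC2)cc1` has not been measured. It differs from compound 2 in one place: 4-methylphenyl in place of 3-chlorophenyl on a saturated ring carbon. Within the data shown here, with no measured single-place step to lean on, and the whole series spanning only a modest range in this assay, the expected step for compound 4 is a small one, not beyond the scatter, with no direction that the data would favour. The step this estimate implies, a number 3 percentage points higher from compound 2 to compound 4 (within the scatter), is therefore expected to be close to nothing. Compound 4 is expected to give 18%, with a likely range from 5% to 38%.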

Compound 4, a percentage reported as activity, at one concentration (the size of the read-out at that concentration, not a potency): 12%
The estimate for compound 4 lay 6 percentage points above the measured number; the range from low to high includes it.
By their numbers in this assay, from the lowest: compounds 1, 4 and 2 (each within the scatter of the next); then compound 3.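

In this assay, within the data shown here, the change to 4-methylphenyl in place of 3-chlorophenyl on the saturated ring carbon gives the series its first single-place step, a number 3 percentage points lower from compound 2 to compound 4 (within the scatter), and so the first direct reading at this position. The two groups match in what is counted for them, each with one six-membered aromatic ring of carbon only, no hydrogen-bond donors or acceptors and no net charge, and this read-out does not separate them. Nothing measured here offers a reason for this step or for its size.

Going by these compounds, this single step changes both the substituent and its place on the phenyl ring, so the separate contributions of the two changes stay open, and 3-methylphenyl or 4-chlorophenyl at the same ring carbon would be needed to tell them apart. The compounds shown also leave open whether a phenyl ring bearing a carboxylic acid or an amine, or a longer alkyl chain in place of the phenyl ring, would give a step beyond the scatter at this position.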